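Salicylanilide cytotoxicity: from compound 2 to compound 3

A few compounds are considered here, and "the series" means these few. Any claim that something is new, unique, unknown or untested is made for them only; others in the source may bear on it.

Measured compounds:
- compound 1, `CCN(CC)c1ccc(NC(=O)c2cc(Cl)ccc2O)c(Cl)c1`: 55500 nM
- compound 2, `O=C(Nc1ccc(NC2CCCC2)cc1Cl)c1ccccc1O`: "not determined" (no result reported)

Compound 1 was tested in an ADME assay on A549 cells (Homo sapiens) for cytotoxicity, read by resazurin assay, with a stated time of 48 h (on this read-out lower numbers stand for higher toxicity in this test and higher numbers for lower toxicity in this test), and gave 55500 nM. Compound 2 was also included in this assay, but for compound 2 the result is recorded as "not determined" (no result reported), so no number stands against it, and nothing can be said about how it compares with compound 1 in this assay.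

Compound 3, `Cc1ccc(O)c(C(=O)Nc2ccc(NC3CCCC3)cc2Cl)c1`, is the next compound and has not yet been measured. It differs from compound 2 in one place: methyl in place of hydrogen on an aromatic carbon. Within the data shown here, with no measured step between any two compounds, there is no ground for expecting a large shift in this assay; the single value for compound 1 points to a region of low toxicity, and a change of this size is expected to move the read-out little, if at all, beyond the scatter in either direction.

Compound 3 is therefore estimated to give 40000 nM in this assay, with an expected range from 12000 nM to 120000 nM.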

Compound 3, half-maximal cytotoxic concentration: 30900 nM
Estimate against measurement, compound 3: 1.3-fold (0.11 log units) above; low and high end bracket the measured number.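

Among these compounds, with no number standing against compound 2 in this assay, no step from it to compound 3 can be read. The compounds shown leave open how methyl in place of hydrogen, para to the hydroxy group, bears on this read-out. Nothing shown offers an explanation for the value of compound 3.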